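Methoxy to dimethylamino: what to expect for compound 4

A few compounds are considered here, and "the series" means these few. Any claim that something is new, unique, unknown or untested is made for them only; others in the source may bear on it.

Measured compounds and their values:
compound 1 `COc1ccc(C2CC(c3ccccc3)=NN2C2=NC(=O)/C(=C3\C(=O)Nc4ccccc43)S2)cc1` gives 2000 nM;
compound 2 `COc1ccc(C2CC(c3ccccc3)=NN2C2=NC(=O)/C(=C3\C(=O)Nc4ccc(Br)cc43)S2)cc1` gives 210 nM;
compound 3 `COc1ccc(C2=NN(C3=NC(=O)/C(=C4\C(=O)Nc5ccc(Br)cc54)S3)C(c3ccc(OC)cc3)C2)cc1` gives 190 nM.

These numbers come from a functional assay on cells (Melanoma cell, Homo sapiens) for cytotoxicity, read by sulforhodamine B assay, with a stated time of 48 h; on this read-out lower numbers stand for stronger inhibition of growth and higher numbers for weaker inhibition of growth. Compound 2 stands second highest of the three. Its nearest neighbour is compound 3, reached by a 1.1-fold lower number from compound 2 to compound 3 (0.04 log units; within the scatter), a difference too small to mean anything. Its furthest neighbour is compound 1, and that gap, a 9.5-fold lower number from compound 1 to compound 2 (0.98 log units; beyond the scatter), is real.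

Compound 4 `CN(C)c1ccc(C2CC(c3ccccc3)=NN2C2=NC(=O)/C(=C3\C(=O)Nc4ccc(Br)cc43)S2)cc1` has not been measured. It differs from compound 2 in one place: dimethylamino in place of methoxy on an aromatic carbon.

Among the compounds with values here, no measured step swaps methoxy for dimethylamino, so the expectation rests on what is nearby. Within the data shown here, the only change made on a six-membered carbon ring of the shared core, a 1.1-fold lower number from compound 2 to compound 3 (0.04 log units; within the scatter), stayed within the scatter, which suggests that this part of the molecule tolerates small edits without a clear shift. Among the measured compounds shown here, the single large step, a 9.5-fold lower number from compound 1 to compound 2 (0.98 log units; beyond the scatter), concerns a bromo on a different ring and says nothing about the present change.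

On that basis compound 4 is expected to show essentially no step beyond the scatter in this assay, namely a 1.1-fold lower number from compound 2 to compound 4 (0.02 log units; within the scatter), giving an estimated 200 nM, within a range from 80 nM to 500 nM.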

Compound 4, concentration for 50% growth inhibition: 200 nM
Compound 4: middle estimate and measured number agree at the digits printed, within the range that was stated.
By their numbers in this assay, from the lowest: compounds 3, 4 and 2 (each within the scatter of the next); then compound 1.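

In this assay, the replacement of methoxy by dimethylamino, para to a large group, gives a 1.1-fold lower number from compound 2 to compound 4 (0.02 log units; within the scatter), so compound 2 and compound 4 cannot be told apart on this read-out even though the entering group differs in its atoms, with nitrogen in place of oxygen and 3 heavy atoms against 2. Within the data shown here, the earlier step within the scatter, a 1.1-fold lower number from compound 2 to compound 3 (0.04 log units; within the scatter), added a methoxy on an aromatic carbon elsewhere in the molecule, whereas this result is the first to test an exchange of the group on the 4-methoxyphenyl ring itself. No measurement at hand bears on why these two groups give matching numbers.

On these data alone, whether this position would accept a very different group, such as a carboxylic acid, a primary amine or a longer chain like hexyloxy, remains open, and so does the result of plain hydrogen there. As far as these compounds go, compound 2 and compound 4 both carry the bromo, so it also remains open whether the same match between methoxy and dimethylamino would hold on the core of compound 1, which lacks it.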